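Aryl variation on the styryl chain: cytotoxicity notes

A few compounds are considered here, and "the series" means these few. Any claim that something is new, unique, unknown or untested is made for them only; others in the source may bear on it.

Measured so far:
compound 1 `COC1=C(C)C(=O)/C(=C(O)/C=C/c2ccccc2OC)C(=O)C1(C)C` — 1.7 ug/mL
compound 2 `COC1=C(C)C(=O)/C(=C(O)/C=C/c2ccc(C)cc2)C(=O)C1(C)C` — 2.4 ug/mL
compound 3 `CCc1ccc(/C=C/C(O)=C2/C(=O)C(C)=C(OC)C(C)(C)C2=O)cc1` — "not determined" (no result reported)

In a functional assay on HUVEC cells (Homo sapiens) for cytotoxicity (a lower number here means that less compound is needed, a higher number that more compound is needed for the effect), compound 1 gives 1.7 ug/mL and compound 2 gives 2.4 ug/mL. Among the measured compounds shown here, the only step between measured compounds that differ in one place is a 1.4-fold higher number from compound 1 to compound 2 (0.15 log units; within the scatter); it concerns an exchange of the aryl group on a double-bonded chain carbon bound to a double-bonded chain carbon, and it stays within the scatter. In this assay compound 3 gives "not determined" (no result reported), so it stands nowhere on the scale shown; its 4-ethylphenyl on the same kind of chain position is untested, and nothing can be read from it directly.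

Compound 4 `C=Cc1ccccc1/C=C/C(O)=C1/C(=O)C(C)=C(OC)C(C)(C)C1=O` differs from compound 3 by 2-vinylphenyl in place of 4-ethylphenyl on a double-bonded chain carbon bound to a double-bonded chain carbon. For the measured compounds named here, the one measured step that bears on an aryl exchange at this position, from compound 1 to compound 2, produced no change beyond the scatter. On that basis no step beyond the scatter is expected in this assay for an aryl exchange here, and the anchor for compound 4 has to be the values of compounds 1 and 2 rather than any number for compound 3.

Compound 4 is therefore estimated at 2.5 ug/mL in this assay, within a range of 1 ug/mL to 6 ug/mL, the width reflecting the missing value for compound 3.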

Compound 4, concentration for half-maximal effect: 1.1 ug/mL
Beside the measured number, compound 4's estimate is 2.3-fold (0.36 log units) above it; low and high end bracket the measured number.
By their numbers in this assay, from the lowest: compounds 4, 1 and 2 (each within the scatter of the next, the first and the last beyond it).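

In this assay, the aryl group on a double-bonded chain carbon bound to a double-bonded chain carbon now gives its first step beyond the scatter: with 2-vinylphenyl in place of 4-methylphenyl, there is a 2.2-fold lower number from compound 2 to compound 4 (0.34 log units; beyond the scatter), a modest change. With vinyl in place of methoxy on an aromatic carbon, there is a 1.5-fold lower number from compound 1 to compound 4 (0.19 log units; within the scatter), which stays within the scatter, so these two groups cannot be told apart here. The aryl position therefore accepts a vinyl group without losing activity in this assay, and the one step beyond the scatter so far is the one that also moves the substituent from the 4-numbered to the 2-numbered ring carbon; no evidence on the compounds shown accounts for either step.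

Still open, going by these compounds, is whether the step to compound 4 follows the numbered ring carbon or the group itself, as 4-methylphenyl and 2-vinylphenyl differ in both at once. On these data alone, how an aryl group carrying an amine, a carboxylic acid or a longer chain would behave at this position also stays open, as does whether any such group would move the number further than the modest step seen here.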